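Hydroxy for chloro on the pendant phenyl of a pyrazoline sulfonamide

The source may hold more compounds than are shown below. What is called first, only, known or untested is meant among the compounds shown, and "the series" means these compounds.

Measured compounds:
compound 1, `NS(=O)(=O)c1ccc(N2N=C(c3cccc(O)c3)C[C@H]2c2ccc(Cl)cc2)cc1`, 19.2%
compound 2, `NS(=O)(=O)c1ccc(N2N=C(c3cccc(O)c3)C[C@H]2c2ccc(O)cc2)cc1`, 64.7%
compound 3, `NS(=O)(=O)c1ccc(N2N=C(c3cccc(O)c3)C[C@H]2c2ccccc2Cl)cc1`, 32.6%

The three measured compounds share a core and were tested in a functional assay on the whole organism (strain Wistar albino) for inhibition, with Rattus norvegicus as the target, read by paw edema, with stated times of 30 min and 3 h, at a dose of 0.05 mmol/kg; a higher number here means more inhibition at the dose given (going by the name of the read-out), a lower number less inhibition. Compound 1 gives 19.2% in this assay, compound 2 gives 64.7%, and compound 3 gives 32.6%. The change from compound 1 to compound 2 is hydroxy in place of chloro on an aromatic carbon, and it produced a number 45.5 percentage points higher from compound 1 to compound 2 (beyond the scatter). Compound 3 differs from compound 1 in its core by 2-chlorophenyl in place of 4-chlorophenyl on a saturated ring carbon, which gave a number 13.4 percentage points higher from compound 1 to compound 3 (beyond the scatter); compound 2 and compound 3 are separated by a number 32.1 percentage points lower from compound 2 to compound 3 (beyond the scatter).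

Compound 4, `NS(=O)(=O)c1ccc(N2N=C(c3cccc(O)c3)C[C@H]2c2ccccc2O)cc1`, is not yet measured. It differs from compound 3 by hydroxy in place of chloro on an aromatic carbon, the same kind of change as that from compound 1 to compound 2, though the place is not the same: in compound 2 the hydroxy stands para to a large group, whereas in compound 4 it stands ortho to a large group. Resting on the large step from compound 1 to compound 2, compound 4 is expected to rise from compound 3 by a number 27.4 percentage points higher from compound 3 to compound 4 (beyond the scatter), a somewhat smaller step because a number 45.5 percentage points higher from compound 1 to compound 2 (beyond the scatter) arose at a different place. The estimate for compound 4 in this assay is 60%, between 40% and 78%.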

Compound 4, a percentage reported as inhibition, in the whole organism at one dose (the size of the read-out at that dose, not a potency): 35.4%
The estimate for compound 4 lay 24.6 percentage points above the measured number; the whole stated range lies above it.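

In this assay, hydroxy in place of chloro did not carry over from one core to the other with the same size: the same change on two cores in this assay, a number 45.5 percentage points higher (beyond the scatter) from compound 1 to compound 2 and a number 2.8 percentage points higher (within the scatter) from compound 3 to compound 4, 42.7 percentage points apart, beyond the scatter of two such steps. With the hydroxy kept and only the aryl group changed, 2-hydroxyphenyl in place of 4-hydroxyphenyl gave a number 29.3 percentage points lower from compound 2 to compound 4 (beyond the scatter), while 2-hydroxyphenyl in place of 4-chlorophenyl gave a number 16.2 percentage points higher from compound 1 to compound 4 (beyond the scatter), and the exchange of chloro for hydroxy on the 2-substituted phenyl gave only a number 2.8 percentage points higher from compound 3 to compound 4 (within the scatter). This shows that the large gain seen with the 4-substituted phenyl cannot be assumed for the 2-substituted one, but two pairs cannot show why the steps differ or how the change would behave on any further core.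

As far as these compounds go, whether an amine or a methoxy group in place of the hydroxy of compound 2 would hold its value remains open. Each value is also a reading at a single dose, so the compounds shown leave their potency unsettled.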